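Amino for methyl on an amide-type nitrogen

The compounds below may be only part of what the source reports. "The series", "measured", "known", "first", "only" and "open" are said of these compounds alone.

Values so far in a toxicity assay on HEK293 cells (Homo sapiens) for inhibition, read by resazurin assay, with a stated time of 24 h; on this read-out higher numbers stand for lower toxicity in this test and lower numbers for higher toxicity in this test:
- compound 1 `CC(NC(=O)c1ncc([N+](=O)[O-])n1C)c1ccc(F)cc1`: > 100000 nM (a limit)
- compound 2 `CNC(=O)c1nc([N+](=O)[O-])cn1Cc1ccc(OC(F)(F)F)cc1`: > 100000 nM (a limit)

Compound 2 stands at > 100000 nM as a limit of the assay and not as a number. Among the compounds with values here, neither compound gives a number, and the evidence so far amounts to the limit of > 100000 nM in this assay, at which 2 of the 2 values shown sit, with no measured step to size a structural change.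

Compound 3 `NNC(=O)c1nc([N+](=O)[O-])cn1Cc1ccc(OC(F)(F)F)cc1` differs from compound 2 by amino in place of methyl on an amide-type nitrogen.

The expected step of a number no higher from compound 2 to compound 3 (the limit leaves the size open) is estimated to stay within the usual scatter, and any shift is expected towards lower numbers. Compound 3 is expected at 100000 nM in this assay, with an estimated range from 40000 nM to 200000 nM, and it may again read only as a limit.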

Compound 3, half-maximal cytotoxic concentration: > 100000 nM
Compound 3: a limit, no number; the forecaster's own chance of this, stated with the estimate: 70%; the middle value lies on the limit itself.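

Compound 2 and compound 3 both give only limits in this assay, and no step can be read for amino in place of methyl on an amide-type nitrogen. The compounds shown leave open whether any change on the shared core would give a measured number in this assay.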